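Chain lengthening on a pyrazoline carbamate: compound 4 expected

The compounds below may be only part of what the source reports. "The series", "measured", "known", "first", "only" and "open" are said of these compounds alone.

Compound 1, `COC(=O)N1N=C(c2ccccc2)CC1c1cc(OC)c(OC)c(OC)c1`: 3950 nM
Compound 2, `CCOC(=O)N1N=C(c2ccccc2)CC1c1cc(OC)c(OC)c(OC)c1`: 5950 nM
Compound 3, `CCOC(=O)N1N=C(c2cccc(OC)c2)CC1c1cc(OC)c(OC)c(OC)c1`: 5820 nM

These three compounds were tested in a functional assay on HepG2 cells (Homo sapiens) for antiproliferative activity, read by MTT assay, with a stated time of 48 h; a higher number here means a weaker inhibitor of growth, a lower number a stronger inhibitor of growth. Compound 1 gives 3950 nM in this assay, and compound 2 gives 5950 nM. The change between them is methyl in place of hydrogen on a saturated chain carbon bound to an oxygen next to a carbonyl group; this step is a 1.5-fold higher number from compound 1 to compound 2 (0.18 log units; within the scatter). Compound 3 gives 5820 nM in this assay, and the step of a 1.0-fold lower number from compound 2 to compound 3 (0.01 log units; within the scatter) is likewise small.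

Compound 4, `CCCOC(=O)N1N=C(c2cccc(OC)c2)CC1c1cc(OC)c(OC)c(OC)c1`, has not yet been measured. It differs from compound 3 by methyl in place of hydrogen on a saturated chain carbon, two bonds along the chain from an oxygen next to a carbonyl group. This is the same kind of change as that from compound 1 to compound 2, but the place is not identical: in the earlier pair the methyl enters on a saturated chain carbon bound to an oxygen next to a carbonyl group, whereas here it enters two bonds along the chain from that oxygen. The difference between the core of compound 1 and the core of compound 3 is not broken down here.

Because the earlier step of a 1.5-fold higher number from compound 1 to compound 2 (0.18 log units; within the scatter) stayed within the scatter, compound 4 is expected to show a similarly small step, a 1.1-fold higher number from compound 3 to compound 4 (0.05 log units; within the scatter). Compound 4 is therefore estimated at 6500 nM in this assay, with a likely range from 3500 nM to 13000 nM.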

Compound 4, concentration for 50% growth inhibition: > 10000 nM
Compound 4: no number, only a limit (the forecaster's own chance of this, stated with the estimate: 5%); at least 1.5-fold (0.18 log units) between middle value and limit.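

In this assay compound 4 gives > 10000 nM, which is a limit of the assay and not a number. The methyl that turns ethoxy into propoxy gives an at least 1.7-fold higher number from compound 3 to compound 4 (0.23 log units; that floor lies within the scatter), and this shows neither that the change carries over unaltered from one core to the other nor that it behaves differently there, the more so as the methyl enters at a different place on the chain in each pair: the same change on two cores in this assay, a 1.5-fold higher number (0.18 log units; within the scatter) from compound 1 to compound 2 and an at least 1.7-fold higher number (0.23 log units; that floor lies within the scatter) from compound 3 to compound 4; the limit leaves it open whether they differ The size of the new step stays unknown, and only its floor can be read: the limit of > 10000 nM in this assay, at which 1 of the 4 values shown sits.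

The compounds shown leave open what the propoxy group would give on the core of compound 1, which would set the same chain on two cores side by side. They also leave open how a longer chain such as butoxy, or an amine carried at the end of the chain, would read in this assay.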